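Dechlorination of a chalcone amide in an antiproliferative assay

The source may report more compounds than this note shows. Statements on the series, on what has been measured and on what is new or still open speak of the compounds shown alone.

Three compounds were tested in a functional assay on MCF7 cells (Homo sapiens) for antiproliferative activity, read by MTT assay, with a stated time of 72 h; on this read-out higher numbers stand for weaker inhibition and lower numbers for stronger inhibition. Within the data shown here, compound 1 `O=C(COc1ccc(C(=O)/C=C/c2cccc(Cl)c2)cc1)N[C@H]1CCOC1=O` gives 20900 nM, the only value in this assay that is a number rather than a limit. Compound 2 `CC(C)c1ccc(NCC(=O)N[C@H]2CCOC2=O)cc1` reaches only the limit of this assay, reported as > 64000 nM. Compound 3 `O=C(CNc1ccc(Cl)cc1Cl)N[C@H]1CCOC1=O` likewise reaches only the limit of this assay, reported as > 64000 nM. Among the measured compounds shown here, because of the limit of > 64000 nM in this assay, at which 2 of the 3 values shown sit, compound 1 is the sole anchor for any comparison here.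

The account now turns from compound 1 to compound 4 `O=C(COc1ccc(C(=O)/C=C/c2ccccc2)cc1)N[C@H]1CCOC1=O`, which differs from compound 1 by the change (hydrogen in place of chloro on an aromatic carbon). For the measured compounds named here, no step between measured compounds touches this position, so nothing measured shows how this change acts. Going by the values given here, since compound 1 carries the only number in this assay, at 20900 nM, the expectation is a modest move, if any: for compound 4 a step of about a 1.4-fold higher number from compound 1 to compound 4 (0.16 log units; within the scatter) is estimated, pointing toward weaker inhibition but likely within the scatter. Compound 4 is therefore expected to give about 30000 nM, within the range 10000 nM to 90000 nM.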

Compound 4, half-maximal inhibitory concentration: > 64000 nM
Compound 4 gave a limit, no number (the forecaster's own chance of this, stated with the estimate: 25%); middle value at least 2.1-fold (0.32 log units) away from the limit.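

Until this step, nothing measured touched this position. In this assay, replacing 3-chlorophenyl with phenyl gives an at least 3.0-fold higher number from compound 1 to compound 4 (0.48 log units; beyond the scatter), so for this pair the single chlorine atom separates a measurable value from none, and the change cannot be dismissed as lying within the scatter. The result for compound 4 is a limit and not a number, so the full size of the step remains unknown, and compound 4 joins the other compounds at that limit: the limit of > 64000 nM in this assay, at which 3 of the 4 values shown sit.

The compounds shown leave open whether another group on this aromatic carbon, such as fluoro, methoxy or an amine, would retain a value like that of compound 1, at 20900 nM. They also leave open whether a chloro group on a different carbon of this ring would do the same.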